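Replacing quinolinyl with methoxyphenyl in an enone series

A few compounds are considered here, and "the series" means these few. Any claim that something is new, unique, unknown or untested is made for them only; others in the source may bear on it.

Measured so far:
- compound 1, `O=C(/C(=C\c1ccc2ccccc2n1)SCc1ccc(F)cc1)c1ccc(Br)cc1`: 25000 nM
- compound 2, `O=C(/C(=C\c1c(O)cc(O)cc1O)Sc1ccccc1Br)c1ccc(Br)cc1`: > 100000 nM
- compound 3, `O=C(/C(=C\c1ccc(O)c([N+](=O)[O-])c1)S(=O)(=O)Cc1ccccc1Cl)c1ccc(Cl)cc1`: 10000 nM

In a functional assay on DU-145 cells (Homo sapiens) for inhibition, read by trypan blue exclusion, with a stated time of 96 h (on this read-out lower numbers stand for stronger inhibition of growth and higher numbers for weaker inhibition of growth), compound 1 gives 25000 nM, the highest of the two numbers reported. Compound 3 sits nearest to it in this assay with 10000 nM, a gap beyond the scatter. For compound 2 this assay reports only a limit, > 100000 nM, not a number (the limit of > 100000 nM in this assay, at which 1 of the 3 values shown sits).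

Compound 4, `COc1ccccc1/C=C(/SCc1ccc(F)cc1)C(=O)c1ccc(Br)cc1`, is yet to be measured in this assay. It differs from compound 1 in one place: 2-methoxyphenyl in place of quinolin-2-yl on a double-bonded chain carbon bound to a double-bonded chain carbon.

Going by the values given here, no step between measured compounds that differ in one place is available, and none of the three measured compounds shares this change, so the expectation rests on compound 1 alone. The step from compound 1 to compound 4 is expected to be small, no change at the digits printed from compound 1 to compound 4 (within the scatter), with no direction beyond the scatter. Compound 4 is therefore estimated at 25000 nM in this assay, with a range from 8000 nM to 80000 nM.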

Compound 4, concentration for 50% growth inhibition: 10000 nM
For compound 4 the middle estimate is 2.5-fold (0.40 log units) above the measured one; the measured number falls inside the stated range.
By their numbers in this assay, from the lowest: compounds 3 and 4 (each within the scatter of the next); then compound 1. At a limit, above all of these: compound 2.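

Going by these compounds alone, the change from quinolin-2-yl to 2-methoxyphenyl gives the first readable step: in this assay there is a 2.5-fold lower number from compound 1 to compound 4 (0.40 log units; beyond the scatter). At this place on a double-bonded chain carbon bound to a double-bonded chain carbon, growth inhibition therefore does not depend on the quinolin-2-yl group, as the smaller 2-methoxyphenyl, with only a carbon ring, gives a modest gain. Nothing measured here accounts for this step.

The compounds shown leave open whether the gain belongs to the methoxy group or to the loss of the quinolin-2-yl ring system, a question that a plain phenyl group at the same place would address. Going by these compounds, it also remains open whether a dimethylamino group in place of the methoxy group would keep the gain, or whether the step holds on other versions of the core.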